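Swapping the acrylic acid for an oxyisobutyric acid

This account rests on a few compounds, and the source may have more. Where it says the series, first, only, none or still open, it means among the compounds named here.

Of the compounds shown here, three have been tested in a functional assay on CHO cells for agonist activity at Free fatty acid receptor 1 (Homo sapiens); a lower number here means that less compound is needed, a higher number that more compound is needed for the effect. Compound 2 `O=C(O)/C=C/c1ccc(NCc2cccc(Oc3ccccc3)c2)cc1` gives 145 nM, the highest of the two numbers recorded, so it needs more compound than its nearest neighbour. That neighbour is compound 3 `Cc1nc(-c2ccc(C(F)(F)F)cc2)sc1CNc1ccc(/C=C/C(=O)O)cc1`, which in this assay gives 36.3 nM; the gap between the two lies beyond the usual scatter. Compound 1 `Cc1nc(-c2ccc(C(F)(F)F)cc2)sc1CNc1ccc(C(=O)O)cc1` is reported only as a limit, < 10000 nM, not as a number. Within the data shown here, because of this limit of < 10000 nM in this assay, at which 1 of the 3 values shown sits, the one step between measured compounds, a step that the limit leaves unreadable from compound 1 to compound 3, has no readable size.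

Compound 4 `CC(C)(Oc1ccc(NCc2cccc(Oc3ccccc3)c2)cc1)C(=O)O` has not yet been measured. It differs from compound 2 by 1-carboxy-1-methylethoxy in place of 2-carboxyethenyl on an aromatic carbon. Among the measured compounds shown here, no measured step exchanges the acid-bearing chain in this way: the single step recorded, from compound 1 to compound 3, concerns a different pair of acid groups and cannot be sized. The expectation for compound 4 therefore rests on little firm ground. Compound 4 is estimated at 1000 nM in this assay, with a range from 150 nM to 8000 nM. This estimate means an expected step of a 6.9-fold higher number from compound 2 to compound 4 (0.84 log units; beyond the scatter) towards a higher number, with wide uncertainty.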

Compound 4, half-maximal effective concentration: < 10000 nM
Compound 4 gave a limit, no number; the forecaster's own chance of this, stated with the estimate: 25%; the middle value does not contradict the limit.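

Compound 4 gave a limit and not a number, so no size can be read for the step from compound 2 to compound 4, and the evidence is this: the limit of < 10000 nM in this assay, at which 2 of the 4 values shown sit.

The compounds shown leave open how much compound 4 really needs in this assay, and whether 1-carboxy-1-methylethoxy in place of 2-carboxyethenyl raises or lowers the number at all.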